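A few compounds are considered here, and "the series" means these few. Any claim that something is new, unique, unknown or untested is made for them only; others in the source may bear on it.

Compound 1 `O=C(O)CCCCOc1cc(-c2ccccc2)cc(-c2ccccc2)n1` carries an acid on a chain that is joined through an oxygen to the shared core. In a functional assay on cells for inhibition of leukotriene B4 receptor 1 (Homo sapiens) (on this read-out higher numbers stand for weaker inhibition and lower numbers for stronger inhibition), compound 1 gives 20000 nM. Compound 2 `O=C(O)CCCCCOc1cc(-c2ccccc2)cc(-c2ccccc2)n1` has the same core with the chain lengthened by one carbon, and in this assay compound 2 gives 2000 nM. Among the measured compounds shown here, the only change measured so far is a 10-fold lower number from compound 1 to compound 2 (1.00 log units; beyond the scatter), so compound 2 stands as the lower of the two numbers, with compound 1 the higher one.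

Compound 3 `CC(CCCCOc1cc(-c2ccccc2)cc(-c2ccccc2)n1)C(=O)O` keeps the chain length of compound 2 and differs from it by methyl in place of hydrogen on a saturated chain carbon bound to a carbonyl carbon and a saturated chain carbon. For the measured compounds named here, no measured step matches this change. The lengthening step from compound 1 to compound 2 concerns the number of chain atoms, whereas here the chain keeps its length and only gains a methyl. A step of no change at the digits printed from compound 2 to compound 3 (within the scatter) in this assay is therefore expected, with nothing beyond the scatter. For compound 3 the estimate in this assay is 2000 nM, within a range from 600 nM to 6000 nM.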

Compound 3, half-maximal inhibitory concentration: 22 nM
Compound 3: middle estimate off by 91-fold (1.96 log units), on the high side; measured number below the stated range.
By their numbers in this assay, from the lowest: compound 3; then compound 2; then compound 1.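

In this assay the methyl on the saturated chain carbon bound to a carbonyl carbon and a saturated chain carbon gives a 91-fold lower number from compound 2 to compound 3 (1.96 log units; beyond the scatter) and counts as a large step, while the earlier lengthening of the chain gave a 10-fold lower number from compound 1 to compound 2 (1.00 log units; beyond the scatter) and counts as a modest one. Placing 1-carboxyethyl instead of carboxy on the chain gives a 910-fold lower number from compound 1 to compound 3 (2.96 log units; beyond the scatter) in all, so this chain carbon, which the earlier pair did not show, responds strongly to a methyl of only one heavy atom. No measurement available here explains why this small addition has so large an effect.

The compounds shown leave open whether an ethyl group or a second methyl on the same carbon would lower the number further or raise it again, and whether a methyl at the matching place on the shorter chain of compound 1 would give a similar step. They also leave open whether an amide or an ester could take the place of the carboxylic acid on the methyl-bearing chain of compound 3.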